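Oxime carbamates of a sugar-like core against alpha-galactosidase

The compounds below may be only part of what the source reports. "The series", "measured", "known", "first", "only" and "open" are said of these compounds alone.

Compound 1, `O=C(Nc1ccccc1)O/N=C1\N[C@H](CO)[C@@H](O)[C@H](O)[C@H]1O`, gives in an assay on isolated protein for inhibition of alpha-galactosidase (Coffea arabica) (on this read-out higher numbers stand for weaker inhibition and lower numbers for stronger inhibition), the value > 100000 nM, which is a limit of the assay.
Compound 2, `O=C(Nc1cccc2ccccc12)O/N=C1\N[C@H](CO)[C@@H](O)[C@H](O)[C@H]1O`, gives in this assay the value > 100000 nM, also a limit.
Compound 3, `O=C(Nc1c(Cl)cccc1C(F)(F)F)O/N=C1\N[C@H](CO)[C@@H](O)[C@H](O)[C@H]1O`, gives in this assay the value > 100000 nM, again a limit.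

Compound 1 therefore stands at the edge of what the test can read: nothing distinguishes it from the other two, since all three sit at the limit of > 100000 nM in this assay, at which 3 of the 3 values shown sit. Compound 4, `CSc1ccc(NC(=O)O/N=C2\N[C@H](CO)[C@@H](O)[C@H](O)[C@H]2O)cc1`, differs from compound 1 by methylsulfanyl in place of hydrogen on an aromatic carbon. Going by the values given here, with no resolved step among the measured compounds, the expected step that the limit leaves unreadable from compound 1 to compound 4 is none beyond the scatter. Compound 4 is estimated at 150000 nM, within 50000 nM to 500000 nM, most likely again reported only as a limit.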

Compound 4, half-maximal inhibitory concentration: > 100000 nM
Compound 4 was reported as a limit; the forecaster's own chance of this, stated with the estimate: 85%; the middle value lies beyond the limit too.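

No step can be read from compound 1 to compound 4, since both values are limits: the limit of > 100000 nM in this assay, at which 4 of the 4 values shown sit.

The compounds shown leave open how strongly any of them inhibits in this assay, and whether methylsulfanyl in place of hydrogen changes that at all.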